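The source may report more compounds than this note shows. Statements on the series, on what has been measured and on what is new or still open speak of the compounds shown alone.

Measured so far in an ADME assay on Huh-7 cells (Homo sapiens) for cytotoxicity, read by MTT assay, with a stated time of 4 h, at 37 degrees C; a higher number here means that more compound is tolerated, a lower number that less compound is tolerated:
- compound 1 `COCCn1c(=O)c(-c2c(Cl)cccc2Cl)cc2c(N)nc(Nc3ccccc3)nc21`: 241000 nM
- compound 2 `CCCCCNc1nc(N)nc2c1cc(-c1ccc(F)cc1)c(=O)n2C`: 79800 nM
- compound 3 `O=C1Nc2nc(Nc3ccccc3)nc(On3nnc4ccccc43)c2CC1c1ccc(F)cc1`: 12200 nM

Compound 2 stands in the middle of these numbers. Compound 1 lies above it and compound 3 below it, and both gaps go beyond the usual scatter of repeated measurements. Compound 4 `Cn1c(=O)c(-c2ccc(F)cc2)cc2c(N3CCCC3)nc(N)nc21` has not yet been measured in this assay. It keeps the core of compound 2 but carries pyrrolidin-1-yl in place of pentylamino on an aromatic carbon. The swap therefore closes the open chain into a ring. Going by the values given here, no two measured compounds differ in only one place, so the data give no direct guide to the effect of this change. The best anchor is compound 2 at 79800 nM, and only a small change is expected. The expected step, a 1.4-fold higher number from compound 2 to compound 4 (0.14 log units; within the scatter), points slightly towards more compound being tolerated and may not clear the scatter. For compound 4 the estimated half-maximal cytotoxic concentration is 110000 nM, with an expected range of 40000 nM to 300000 nM.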

Compound 4, half-maximal cytotoxic concentration: 111000 nM
Compound 4: middle estimate off by 1.0-fold (0.00 log units), on the low side; measured number inside the range.
By their numbers in this assay, from the lowest: compound 3; then compounds 2 and 4 (each within the scatter of the next); then compound 1.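

In this assay, going by these compounds alone, this pair gives the first direct comparison at this aromatic carbon, next to the ring nitrogen, with a 1.4-fold higher number from compound 2 to compound 4 (0.14 log units; within the scatter). Replacing the open pentylamino chain with the closed pyrrolidin-1-yl ring also removes the hydrogen-bond donor on the attached nitrogen, yet the two compounds cannot be told apart here. So, for this pair on this core, neither difference produces a change that can be read in this measurement, and no measurement shown explains why the two compounds match.

From the compounds shown here alone, it remains open whether a group of another kind at this carbon, such as a morpholine ring or a carboxylic acid on the chain, would move the number beyond the scatter. It is also unknown whether the same swap would give a similar result on a different core.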